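Working notes: chain length on the shared core

The compounds below may be only part of what the source reports. "The series", "measured", "known", "first", "only" and "open" are said of these compounds alone.

Compound 1 `CCCCCCCCCC(=O)Nc1nnc(S[C@@H]2O[C@H](CO)[C@H](O)[C@H](O)[C@H]2O)s1` gives 53100 nM
Compound 2 `CCCCCC(=O)Nc1nnc(S[C@@H]2O[C@H](CO)[C@H](O)[C@H](O)[C@H]2O)s1` gives 28700 nM

In a functional assay on MDA-MB-231 cells (Homo sapiens) for cytotoxicity, read by MTT assay, with a stated time of 24 h (on this read-out lower numbers stand for stronger inhibition and higher numbers for weaker inhibition), compound 2 stands at 28700 nM and compound 1 at 53100 nM in the same read-out. The two values lie within the scatter of each other, so neither ranks ahead.

The change to compound 3 `CCCCCCCCCCCCCCCC(=O)Nc1nnc(S[C@@H]2O[C@H](CO)[C@H](O)[C@H](O)[C@H]2O)s1` is decyl in place of hydrogen on a saturated chain carbon, five bonds along the chain from a carbonyl carbon and it extends the same chain. Among the compounds with values here, the one measured step bearing on this is a 1.9-fold lower number from compound 1 to compound 2 (0.27 log units; within the scatter) with butyl giving way to hydrogen at that place. Decyl is a larger group than that butyl, and the single step gives thin support. Even so, no step beyond the scatter is expected in this assay and only a weak lean towards a higher number. The expected size is a 1.6-fold higher number from compound 2 to compound 3 (0.20 log units; within the scatter) as estimated here. The estimate for compound 3 is 45000 nM with an expected range of 15000 nM to 120000 nM around it.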

Compound 3, half-maximal inhibitory concentration: 62300 nM
Beside the measured number, compound 3's estimate is 1.4-fold (0.14 log units) below it, and the stated range covers the measured number.
By their numbers in this assay, from the lowest: compounds 2, 1 and 3 (each within the scatter of the next, the first and the last beyond it).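

In this assay, within the data shown here, decyl in place of hydrogen on a saturated chain carbon, five bonds along the chain from a carbonyl carbon, gives a 2.2-fold higher number from compound 2 to compound 3 (0.34 log units; beyond the scatter) and this modest step is the first to lie beyond the scatter. Hexyl in place of hydrogen on a saturated chain carbon, nine bonds along the chain from a carbonyl carbon, gives a 1.2-fold higher number from compound 1 to compound 3 (0.07 log units; within the scatter) so compound 1 stays unseparated from compound 3 as well as from compound 2, and the only separation lies between the shortest and longest chains shown. No measurement available here accounts for this difference.

The compounds shown leave open whether a longer chain than that of compound 3 would continue in the same direction. They also leave open whether an amine or a carboxylic acid at the chain end would shift the number at this place.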